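The source may hold more compounds than are shown below. What is called first, only, known or untested is meant among the compounds shown, and "the series" means these compounds.

Measured so far in a functional assay on K562 cells (Homo sapiens) for cytotoxicity, read by trypan blue exclusion, with a stated time of 96 h; on this read-out higher numbers stand for weaker inhibition and lower numbers for stronger inhibition:
compound 1 `COc1ccc(/C=C/S(=O)(=O)Nc2c(F)c(F)c(F)c(F)c2F)cc1N` gives 35000 nM
compound 2 `COc1cc(OC)c(/C=C/S(=O)(=O)Nc2ccc(F)c([N+](=O)[O-])c2)c(OC)c1` gives 75000 nM
compound 3 `COC(=O)CNc1cc(NS(=O)(=O)/C=C/c2c(OC)cc(OC)cc2OC)ccc1OC` gives 350 nM

Compound 3 stands lowest of the three numbers; compound 1 and compound 2 both sit well beyond the scatter from it, compound 2 the furthest. Compound 4 `COc1cc(OC)c(/C=C/S(=O)(=O)Nc2ccc(OC)c(NC(C(=O)O)c3ccc(Br)cc3)c2)c(OC)c1` follows from compound 3 by one change: (4-bromophenyl)(carboxy)methyl in place of (methoxycarbonyl)methyl on a nitrogen on an aromatic ring. Going by the values given here, no pair of measured compounds differing in one place exists here, so the size of this step is not anchored by any measured step in this assay. The entering group is considerably larger than the leaving one and carries a carboxy in place of a methoxycarbonyl; a shift toward weaker inhibition is expected, roughly a 4.3-fold higher number from compound 3 to compound 4 (0.63 log units; beyond the scatter), though it could stay within the scatter. For compound 4 the estimate in this assay is 1500 nM, with a range from 150 nM to 15000 nM.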

Compound 4, half-maximal inhibitory concentration: 75 nM
Estimate against measurement, compound 4: 20-fold (1.30 log units) above, and the stated range ends above it.
By their numbers in this assay, from the lowest: compound 4; then compound 3; then compound 1; then compound 2.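

In this assay, the nitrogen on the aromatic ring accepts a much larger substituent without loss: (4-bromophenyl)(carboxy)methyl in place of (methoxycarbonyl)methyl gives a 4.7-fold lower number from compound 3 to compound 4 (0.67 log units; beyond the scatter) as a modest gain in inhibition. This single step shows that an aromatic ring and a carboxy can sit together on this nitrogen. No available measurement accounts for the gain.

From the compounds shown here alone, the change alters two features at once, so the separate contributions of the 4-bromophenyl and the carboxy remain open. A methyl ester in place of the carboxylic acid, or a phenyl lacking the bromine, would separate them.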